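The source may report more compounds than this note shows. Statements on the series, on what has been measured and on what is new or still open speak of the compounds shown alone.

Working notes on the series. Compound 1 `CNC(=O)c1cc(Oc2ccc(NC(=O)c3cc4cccnc4n(-c4ccc(Cl)cc4)c3=O)cc2)ccn1` in a functional assay on A549 cells (Homo sapiens) for antiproliferative activity, read by MTT assay, with a stated time of 72 h (on this read-out higher numbers stand for weaker inhibition and lower numbers for stronger inhibition), gives 370 nM. Compound 2 `CNC(=O)c1cc(Oc2ccc(NC(=O)c3cc4cccnc4n(-c4ccc(Br)cc4)c3=O)cc2)ccn1` in this assay gives 1050 nM; the change from compound 1 is bromo in place of chloro on an aromatic carbon, and the step is a 2.8-fold higher number from compound 1 to compound 2 (0.45 log units; beyond the scatter). Compound 3 `CCCNC(=O)c1cc(Oc2ccc(NC(=O)c3cc4cccnc4n(-c4ccc(Cl)cc4)c3=O)cc2)ccn1` in this assay gives 120 nM; it differs from compound 1 by ethyl in place of hydrogen on a saturated chain carbon bound to an amide-type nitrogen, and the step is a 3.1-fold lower number from compound 1 to compound 3 (0.49 log units; beyond the scatter). Compound 3 holds the lowest number of the three measured, with both steps to it beyond the scatter.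

Compound 4 `CCCNC(=O)c1cc(Oc2ccc(NC(=O)c3cc4cccnc4n(-c4ccc(Br)cc4)c3=O)cc2)ccn1` is not yet measured. Its difference from compound 3 is bromo in place of chloro on an aromatic carbon, the same change that separates compound 1 from compound 2, at a place described in the same words; the two pairs differ only in their cores, as told by the propylcarbamoyl change given above.

For compound 4 in this assay a step of about a 2.7-fold higher number from compound 3 to compound 4 (0.43 log units; beyond the scatter) is expected because a 2.8-fold higher number from compound 1 to compound 2 (0.45 log units; beyond the scatter) is what the same change gave. Compound 4 is therefore estimated at 320 nM, within 130 nM to 800 nM.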

Compound 4, half-maximal inhibitory concentration: 150 nM
Compound 4: the middle estimate sits 2.1-fold (0.33 log units) above what was measured, and the stated range covers the measured number.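

On the propylcarbamoyl core, bromo in place of chloro in this assay gives a 1.3-fold higher number from compound 3 to compound 4 (0.10 log units; within the scatter), and this does not differ from the step on the other core by more than two such steps scatter: the same change on two cores in this assay, a 2.8-fold higher number (0.45 log units; beyond the scatter) from compound 1 to compound 2 and a 1.3-fold higher number (0.10 log units; within the scatter) from compound 3 to compound 4, 2.3-fold (0.36 log units) apart, within the scatter of two such steps. Ethyl in place of hydrogen on the chain, read on the bromo pair, gives a 7.0-fold lower number from compound 2 to compound 4 (0.85 log units; beyond the scatter), and it too agrees with its earlier step within that scatter: the same change on two cores in this assay, a 3.1-fold lower number (0.49 log units; beyond the scatter) from compound 1 to compound 3 and a 7.0-fold lower number (0.85 log units; beyond the scatter) from compound 2 to compound 4, 2.3-fold (0.36 log units) apart, within the scatter of two such steps. Both changes thus carry across these two cores without a gap that can be told from scatter, but one pair per core does not show that the steps are equal, and the bromo step lies beyond the scatter on one core and within it on the other, leaving its size on a further core unsettled.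

Only the 4-chlorophenyl and 4-bromophenyl groups and the methyl and propyl amides appear here. As far as these compounds go, whether these steps hold with a fluoro group in place of the halogen, or with a longer chain or a chain ending in an amine on the amide, stays open.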